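The source may hold more compounds than are shown below. What is called first, only, known or untested is meant among the compounds shown, and "the series" means these compounds.

For the measured compounds named here, compound 2 `CC(C)(O)c1cncc(-n2ncc3cc(C(F)(F)F)ccc32)c1` holds the highest of the two numbers measured so far in an ADME assay on cells for inhibition of cytochrome P450 11B1, mitochondrial (Homo sapiens), read by HTRF, with stated times of 1 h and 3 h (a lower number here means a stronger inhibitor, a higher number a weaker inhibitor), where compound 2 gives 1200 nM, while compound 1 `Cc1ccc2c(cnn2-c2cncc(C(C)(C)O)c2)c1` gives 916 nM; the step of a 1.3-fold higher number from compound 1 to compound 2 (0.12 log units; within the scatter) lies within the scatter. Compound 3 `CC(C)(O)c1cncc(-n2ncc3cc(C#N)ccc32)c1` differs from compound 2 by cyano in place of trifluoromethyl on an aromatic carbon. Going by the values given here, the only measured step that bears on this, also an exchange of one group on an aromatic carbon, stayed within the scatter, so the step of a 1.1-fold lower number from compound 2 to compound 3 (0.04 log units; within the scatter) is expected to be no larger than the scatter. Compound 3 is therefore estimated at 1100 nM, within a range from 500 nM to 2500 nM.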

Compound 3, half-maximal inhibitory concentration: > 8300 nM
Compound 3: a limit, no number; the forecaster's own chance of this, stated with the estimate: 5%; middle value at least 7.5-fold (0.87 log units) from the limit.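

In this assay, this aromatic carbon proves not to be indifferent to its group: methyl and trifluoromethyl could not be told apart, yet cyano makes compound 3 clearly the weaker inhibitor, with an at least 6.9-fold higher number from compound 2 to compound 3 (0.83 log units; beyond the scatter) and an at least 9.0-fold higher number from compound 1 to compound 3 (0.95 log units; beyond the scatter). The reading for compound 3 is a limit of the assay, not a number, so both steps give only a lower bound on the change: the limit of > 8300 nM in this assay, at which 1 of the 3 values shown sits.

Cyano differs from trifluoromethyl both in its hydrogen-bond acceptor and in its heavy atom count, and these compounds cannot separate the two. On these data alone, how a methoxy group or an amine on this carbon would read also stays open.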